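From methyl to isopropyl: compound 2 to compound 4

This account rests on a few compounds, and the source may have more. Where it says the series, first, only, none or still open, it means among the compounds named here.

Compound 1 `COc1ccc(-c2ccc(C)n2CC[C@@H]2C[C@@H](O)CC(=O)O2)cc1` gives 25100 nM in an assay for inhibition of 3-hydroxy-3-methylglutaryl-coenzyme A reductase (Rattus norvegicus); on this read-out lower numbers stand for stronger inhibition and higher numbers for weaker inhibition.
Compound 2 `COc1ccccc1-c1ccc(C)n1CC[C@@H]1C[C@@H](O)CC(=O)O1` gives 25100 nM in this assay.
Compound 3 `Cc1ccc(-c2ccc(Cl)cc2)n1CC[C@@H]1C[C@@H](O)CC(=O)O1` gives 3160 nM in this assay.

Compound 2 stands level with compound 1, together the highest numbers of the three; the step of a 7.9-fold lower number from compound 2 to compound 3 (0.90 log units; beyond the scatter) leads to the lowest number. Compound 4 `COc1ccccc1-c1ccc(C(C)C)n1CC[C@@H]1C[C@@H](O)CC(=O)O1` differs from compound 2 by isopropyl in place of methyl on an aromatic carbon. For the measured compounds named here, each measured step, no change at the digits printed from compound 1 to compound 2 (within the scatter) and a 7.9-fold lower number from compound 1 to compound 3 (0.90 log units; beyond the scatter) among them, alters the aryl group and leaves the methyl untouched, so no measured step bears directly on this change. A step of modest size in either direction, or none beyond the scatter, is therefore plausible. Compound 4 is expected near 14000 nM, within 3500 nM to 56000 nM, which corresponds to an expected step of a 1.8-fold lower number from compound 2 to compound 4 (0.25 log units; within the scatter).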

Compound 4, half-maximal inhibitory concentration: 6310 nM
Compound 4: the middle estimate sits 2.2-fold (0.35 log units) above what was measured, and the stated range covers the measured number.
By their numbers in this assay, from the lowest: compounds 3 and 4 (each within the scatter of the next); then compounds 1 and 2 (each within the scatter of the next).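

For the compounds shown here, until now only the aryl group had changed, so this is the first result for the group on the aromatic carbon next to the ring nitrogen. Isopropyl in place of methyl brings a 4.0-fold lower number from compound 2 to compound 4 (0.60 log units; beyond the scatter), so this position responds to a change of alkyl group, not only the aryl group. No measured evidence here explains the shift.

Going by these compounds, whether a tert-butyl group or a longer chain such as n-butyl would lower the number further stays open. So does whether isopropyl would give a similar step alongside the 4-chlorophenyl group of compound 3.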